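A few compounds are considered here, and "the series" means these few. Any claim that something is new, unique, unknown or untested is made for them only; others in the source may bear on it.

Measured so far in a functional assay on MCF7 cells (Homo sapiens) for cytotoxicity, read by MTT assay, with a stated time of 72 h; a lower number here means a stronger inhibitor of growth, a higher number a weaker inhibitor of growth:
compound 1 `CCCCC[Se]c1nc(NCc2ccccc2)c2ccccc2n1` gives 47100 nM.
compound 2 `[SeH]c1nc(NCc2ccccc2)c2ccccc2n1` gives only a limit, > 100000 nM.

Compound 2 thus stands at the edge of what this assay reports: its value is a limit rather than a number, and it sits at the limit of > 100000 nM in this assay, at which 1 of the 2 values shown sits. Within the data shown here, the only measured step is an at least 2.1-fold higher number from compound 1 to compound 2 (0.32 log units; beyond the scatter), hydrogen in place of pentyl on a selenium, and it runs into that limit. Compound 3 `CSc1nc(NCc2ccccc2)c2ccccc2n1` differs from compound 2 by a group of 2 heavy atoms (1 carbon, 1 sulfur; no ring) in place of one selenium atom, on an aromatic carbon. Compound 3, like compound 1, carries a carbon chain on the heteroatom, while compound 2 carries hydrogen there; a modest fall toward the number of compound 1, or no step beyond the scatter, is expected, and a further limit remains possible. Compound 3 is expected at 70000 nM, within 25000 nM to 150000 nM. The estimate means an expected step of an at least 1.4-fold lower number from compound 2 to compound 3 (0.15 log units; that floor lies within the scatter).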

Compound 3, concentration for total growth inhibition: 82800 nM
Compound 3: middle estimate off by 1.2-fold (0.07 log units), on the low side; the range from low to high includes it.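

Compound 3 carries no selenium and still gives a number in this assay, 82800 nM, so a measurable reading at this aromatic carbon between two ring nitrogen atoms does not depend on selenium. The listed step is a 1.8-fold higher number from compound 1 to compound 3 (0.25 log units; within the scatter), so the methylsulfanyl group and the pentyl on selenium cannot be told apart at this position, even though they differ in both the heteroatom and the chain. The other comparison is an at least 1.2-fold lower number from compound 2 to compound 3 (0.08 log units; that floor lies within the scatter), so methylsulfanyl is not shown to differ from the hydrogen-bearing selenium of compound 2, whose value is only a limit: the limit of > 100000 nM in this assay, at which 1 of the 3 values shown sits.

The effects of the heteroatom and the chain remain unseparated, and a pentyl chain on sulfur or a methyl group on selenium would address that. As far as these compounds go, whether an amine or a carboxylic acid at this carbon would give a clearly lower number also remains open.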